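This account rests on a few compounds, and the source may have more. Where it says the series, first, only, none or still open, it means among the compounds named here.

Measured compounds:
- Compound 1, `Cc1cc(OCc2ccccn2)n2nc(C)c(-c3ccccc3)c2n1`, gives 25600 nM in a physicochemical assay for solubility, read by HPLC, using the shake flask method, measured as kinetic solubility, with a stated time of 2 h, at pH 7.4; a lower number here means a less soluble compound, a higher number a more soluble compound.
- Compound 2, `Cc1cc(NCc2ccccn2)n2ncc(-c3cccc(F)c3)c2n1`, gives 5000 nM in this assay.

Of these two numbers, compound 2 holds the lower one; its nearest neighbour is compound 1, whose number is higher by a margin that lies beyond the usual scatter of repeated measurements. Since the two compounds differ in more than one place, nothing can be said about which part of the difference carries that gap; only the two values themselves are known.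

Compound 3, `Cc1cc(NCc2ccccn2)n2ncc(-c3ccsc3)c2n1`, is the next compound to be measured. It is made from compound 2 by a single change: thiophen-3-yl in place of 3-fluorophenyl on an aromatic carbon. Among the measured compounds shown here, no measured pair shows a step of this kind, so there is no precedent to lean on. A small move toward a higher number is expected, but one that may well stay within the scatter. The step from compound 2 to compound 3 is estimated as a 1.5-fold higher number from compound 2 to compound 3 (0.18 log units; within the scatter). In this assay compound 3 is expected to give 7500 nM, with a likely range from 2500 nM to 22000 nM.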

Compound 3, solubility: 9000 nM
Compound 3: the middle estimate sits 1.2-fold (0.08 log units) below what was measured, within the range that was stated.
By their numbers in this assay, from the lowest: compounds 2 and 3 (each within the scatter of the next); then compound 1.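

Among the compounds shown here, the step from 3-fluorophenyl to thiophen-3-yl is the only one here that changes a single place, so it can be read directly. In this assay it shows a 1.8-fold higher number from compound 2 to compound 3 (0.26 log units; within the scatter), even though a six-membered aromatic ring of carbon only gives way to a five-membered aromatic ring with one sulfur. On this aromatic carbon, then, the two rings cannot be told apart in this measurement, and nothing available explains why they read alike.

Going by these compounds, it remains open whether a group of another kind at this position, such as an amine or a carboxylic acid, would produce a step beyond the scatter. The gap between compound 1 and compound 2 also stays unassigned, since those two compounds differ in more than one place.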